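This account rests on a few compounds, and the source may have more. Where it says the series, first, only, none or still open, it means among the compounds named here.

The cytotoxicity of these compounds was followed in an ADME assay on HepG2 cells (Homo sapiens) for cytotoxicity, read by CellTiter-Glo and resazurin assay, with a stated time of 72 h; a higher number here means that more compound is needed for the effect, a lower number that less compound is needed. Compound 1 `CC(C)N(Cc1cccc(OCCCCCC(=O)O)c1)C(=O)c1ccc(-c2ccc(Cl)c(Cl)c2)cc1` reached only the limit of the assay, giving > 26000 nM. Compound 2 `CCOC(=O)CCCCCOc1cccc(CN(C(=O)c2ccc(-c3cccnc3)cc2)C(C)C)c1` likewise stopped at the limit, giving > 26000 nM. Both values sit at the limit of > 26000 nM in this assay, at which 2 of the 2 values shown sit, and no numbered half-maximal effective concentration was obtained for either compound. Compound 3 `CCOC(=O)CCCCCOc1cccc(CN(C(=O)c2ccc(-c3ccc4cc[nH]c4c3)cc2)C(C)C)c1` has not yet been measured. It differs from compound 2 in one place: 1H-indol-6-yl in place of pyridin-3-yl on an aromatic carbon. Within the data shown here, no step between measured compounds stands alongside this change; what the step from compound 2 to compound 3 will do in this assay cannot be read from any measured pair. The expectation is that this change brings no step beyond the usual scatter in this assay, with a step that the limit leaves unreadable from compound 2 to compound 3 expected. Compound 3 is estimated at 30000 nM, within a range from 15000 nM to 80000 nM, and it is expected most likely to remain at the limit of the assay.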

Compound 3, half-maximal effective concentration: > 26000 nM
Compound 3 was reported as a limit; the forecaster's own chance of this, stated with the estimate: 75%; the middle value is on the limit's open side.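

In this assay, compound 3 gives > 26000 nM, which is a limit of the assay and not a number. Compound 2 also stands at a limit, so no step can be read between compound 2 and compound 3: the limit of > 26000 nM in this assay, at which 3 of the 3 values shown sit.

The compounds shown leave open what half-maximal effective concentration any of them has in this assay, and whether 1H-indol-6-yl in place of pyridin-3-yl changes it.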